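A few compounds are considered here, and "the series" means these few. Any claim that something is new, unique, unknown or untested is made for them only; others in the source may bear on it.

Working notes on the series. Compound 2 `COc1ccccc1N1CCN(CCCNc2ncccc2C(=O)N(C)C)CC1` carries a dimethylamide on the shared core; in a functional assay for antagonist activity at Alpha-1A adrenergic receptor (Oryctolagus cuniculus) (on this read-out higher numbers stand for weaker binding and lower numbers for tighter binding), compound 2 gives 1.59 nM. Compound 1 `COc1ccccc1N1CCN(CCCNc2ncccc2C(=O)NC(C)(C)C)CC1` differs from it only at the amide, and in this assay compound 1 gives 1.26 nM; the step of a 1.3-fold higher number from compound 1 to compound 2 (0.10 log units; within the scatter) leaves the two undivided. Compound 3 `COc1ccccc1N1CCN(CCCNc2nc(C)cc(C)c2C(N)=O)CC1` differs from compound 2 in more than one place, so only its value can be set beside them: in this assay compound 3 gives 10 nM. Among the three numbers compound 2 is the second highest, closest to compound 1 and farthest from compound 3.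

Compound 4 `CSc1ccccc1N1CCN(CCCNc2ncccc2C(=O)N(C)C)CC1` has not been measured. It differs from compound 2 in one place: methylsulfanyl in place of methoxy on an aromatic carbon. For the measured compounds named here, no measured step touches this part of the molecule; the single step on record concerns the amide and says nothing about the aromatic substituent. The swap exchanges one small group for another of matching count and hydrogen-bond character, so no step beyond the scatter is expected, only a wider range than usual. Compound 4 is therefore estimated at 2.5 nM in this assay, with a range from 0.8 nM to 8 nM. That estimate corresponds to an expected step of a 1.6-fold higher number from compound 2 to compound 4 (0.20 log units; within the scatter).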

Compound 4, dissociation constant: 0.631 nM
Compound 4: the middle estimate sits 4.0-fold (0.60 log units) above what was measured; the whole stated range lies above it.
By their numbers in this assay, from the lowest: compounds 4, 1 and 2 (each within the scatter of the next, the first and the last beyond it); then compound 3.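

Methylsulfanyl in place of methoxy on an aromatic carbon, ortho to a large group, gives a 2.5-fold lower number from compound 2 to compound 4 (0.40 log units; beyond the scatter) in this assay, so on this read-out the change points to tighter binding. For the compounds shown here, this is the first single-place change to go beyond the scatter, whereas the only earlier one, at the amide, was a 1.3-fold higher number from compound 1 to compound 2 (0.10 log units; within the scatter) and stayed within it; the 2-methoxyphenyl group can therefore be exchanged here without loss, and the position responds to a change even when the group that enters matches the one that leaves in heavy-atom, donor and acceptor counts, with sulfur standing where oxygen stood. Nothing at hand gives a measured basis for explaining the gain, and the step records only its size and direction.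

Still open, from the compounds shown here alone, is whether the same exchange gives a step of similar size when the amide is the tert-butyl amide of compound 1 or the primary amide with the two ring methyl groups of compound 3. The compounds shown also leave open how this position would respond to an ethoxy group, an ethylsulfanyl group, a chlorine atom or a hydroxyl group.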